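A few compounds are considered here, and "the series" means these few. Any claim that something is new, unique, unknown or untested is made for them only; others in the source may bear on it.

Measured so far:
Compound 1, `CCn1c(SCC(=O)Nc2ccc(/C(C)=N/O)cc2)nnc1-c1cc(OC)c(OC)c(OC)c1`, gives 70% in a functional assay on the whole organism (strain albino) for inhibition, with Rattus norvegicus as the target, read by paw edema, with stated times of 30 min and 4 h, at a dose of 0.28 mmol/kg by the oral route; a higher number here means more inhibition at the dose given (going by the name of the read-out), a lower number less inhibition.
Compound 2, `C=CCn1c(SCC(=O)Nc2ccc(C(C)=O)cc2)nnc1-c1ccc(OC)c(OC)c1`, gives 70% in this assay.
Compound 3, `CCn1c(SCC(=O)Nc2ccc(C(C)=O)cc2)nnc1-c1cc(OC)c(OC)c(OC)c1`, gives 68% in this assay.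

Compounds 1 and 3 share one core and differ only in the group on the outer ring: a group of 4 heavy atoms (2 carbon, 1 nitrogen, 1 oxygen; no ring) in place of a group of 3 heavy atoms (2 carbon, 1 oxygen; no ring), on an aromatic carbon. This exchange gave a number 2 percentage points higher from compound 3 to compound 1 (within the scatter), so the two numbers count as the same. Compound 2 carries a different core, with a different ring and a different chain on the triazole; the difference between the two cores is not broken down here. Its value sits level with compound 1 at the digits shown, and all three numbers lie within the usual scatter of one another.

Compound 4, `C=CCn1c(SCC(=O)Nc2ccc(/C(C)=N/O)cc2)nnc1-c1ccc(OC)c(OC)c1`, is not yet measured. It stands to compound 2 exactly as compound 1 stands to compound 3: a group of 4 heavy atoms (2 carbon, 1 nitrogen, 1 oxygen; no ring) in place of a group of 3 heavy atoms (2 carbon, 1 oxygen; no ring), on an aromatic carbon. The exchange occurs twice among these compounds, and the one measured instance barely moved the read-out. On that basis the same kind of change is expected to move compound 2 to compound 4 by a number 1 percentage points higher from compound 2 to compound 4 (within the scatter) in this assay, resting on a number 2 percentage points higher from compound 3 to compound 1 (within the scatter) and on compound 2 starting from 70%. Compound 4 is therefore estimated at 71%, most likely between 60% and 81%.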

Compound 4, a percentage reported as inhibition, in the whole organism at one dose (the size of the read-out at that dose, not a potency): 79%
Compound 4: middle estimate off by 8 percentage points, on the low side; the range from low to high includes it.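

In this assay, putting the new group in place of the acetyl group on the aromatic carbon gave a number 9 percentage points higher from compound 2 to compound 4 (within the scatter). Set beside the same exchange on the other core, the two steps cannot be told apart: the same change on two cores in this assay, a number 2 percentage points higher (within the scatter) from compound 3 to compound 1 and a number 9 percentage points higher (within the scatter) from compound 2 to compound 4, 7 percentage points apart, within the scatter of two such steps The exchange therefore behaves alike on these two cores as far as this read-out can tell, but neither step shows that it really raises inhibition, and two cores are too few to show how it would behave on a third.

The compounds shown leave open whether a clearly different group at this place, such as an amine, a carboxylic acid or a longer chain, would move the read-out beyond the usual scatter. They also leave open how these compounds would compare at other doses, since each value describes the size of the effect at a single dose and not a potency.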